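Indole chain variation against myeloperoxidase

The source may hold more compounds than are shown below. What is called first, only, known or untested is meant among the compounds shown, and "the series" means these compounds.

Of the compounds shown here, two have been measured in an assay on isolated protein (urine) for inhibition of Myeloperoxidase (Homo sapiens), with a stated time of 5 min; on this read-out lower numbers stand for stronger inhibition and higher numbers for weaker inhibition. Compound 1 `NCCCc1c[nH]c2c(F)cccc12` gives 24 nM in this assay. Compound 2 `NCCSCCc1c[nH]c2ccc(F)cc12` gives 4 nM in this assay, the lower of the two numbers; the gap to compound 1 lies beyond the usual scatter, and the two structures differ in more than one place, so the gap is only noted, not assigned to any single change.

Compound 3 `NC(=O)CCCc1c[nH]c2ccc(F)cc12` has not yet been measured. It differs from compound 2 as follows: carbamoylmethyl in place of (2-aminoethyl)sulfanyl on a saturated chain carbon, two bonds along the chain from an aromatic carbon. Within the data shown here, no step between measured compounds isolates such a change, so the expectation rests on the two values shown and on the change itself. The account expects the step from compound 2 to compound 3 to be an increase in the number, that is weaker inhibition, by a 50-fold higher number from compound 2 to compound 3 (1.70 log units; beyond the scatter), a step beyond the scatter. For compound 3 the estimate in this assay is 200 nM, with a range from 40 nM to 2000 nM.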

Compound 3, half-maximal inhibitory concentration: 18 nM
Estimate against measurement, compound 3: 11-fold (1.05 log units) above; the whole stated range lies above it.
By their numbers in this assay, from the lowest: compound 2; then compounds 3 and 1 (each within the scatter of the next).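

In this assay, among these compounds, putting carbamoylmethyl in place of (2-aminoethyl)sulfanyl on a saturated chain carbon, two bonds along the chain from an aromatic carbon, gives a 4.5-fold higher number from compound 2 to compound 3 (0.65 log units; beyond the scatter) as the first change that can be read at a single place. It shows that the chain end matters to inhibition, since two groups of 4 heavy atoms each, with no ring and no net charge, do not give the same number. It also shows that the amine and the sulfur of compound 2 are not both required for inhibition at this level, as compound 3 still gives 18 nM with neither of them in its chain. Nothing measured alongside these values accounts for the size of this step.

As far as these compounds go, the sulfur, the amine and the carbonyl all change in this one step, so their separate shares in it remain open. A plain all-carbon chain ending in an amine, or a carboxylic acid at the chain end, would start to separate those shares.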